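Swapping a ring-nitrogen group in a weak antiproliferative series

A few compounds are considered here, and "the series" means these few. Any claim that something is new, unique, unknown or untested is made for them only; others in the source may bear on it.

Of the compounds shown here, two of a shared core have been tested in a functional assay on HeLa cells (Homo sapiens) for antiproliferative activity, with a stated time of 24 h; on this read-out lower numbers stand for stronger inhibition and higher numbers for weaker inhibition. Compound 1, `N#Cc1ccccc1CN1CCc2c(sc(NC(=O)c3ccccc3Cl)c2C(N)=O)C1`, reaches only the limit of this assay, > 50000 nM, so its value is a boundary rather than a number. Compound 2, `NC(=O)c1c(NC(=O)c2ccccc2F)sc2c1CCN(Cc1ccc(Cl)cc1Cl)C2`, carries a different group on the ring nitrogen and a fluorine instead of chlorine on the aromatic amide; in this assay compound 2 gives 27500 nM. Both results therefore sit at the weak end of the scale, and compound 1 stands at the limit of > 50000 nM in this assay, at which 1 of the 2 values shown sits.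

Compound 3, `COc1ccccc1NC(=S)N1CCc2c(sc(NC(=O)c3ccccc3Cl)c2C(N)=O)C1`, differs from compound 1 in one place: a group of 11 heavy atoms (8 carbon, 1 nitrogen, 1 oxygen, 1 sulfur; one six-membered aromatic ring of carbon only) in place of a group of 9 heavy atoms (8 carbon, 1 nitrogen; one six-membered aromatic ring of carbon only), on an amine nitrogen in a ring. For the measured compounds named here, since the two measured compounds share no single-point step, no measured step gives a direction for this change. Given that compound 1 already reports only the limit > 50000 nM, the expectation is that compound 3 stays weak, with a step of an at least 1.1-fold lower number from compound 1 to compound 3 (0.04 log units; that floor lies within the scatter) that is expected to lie within the usual scatter or to end again at a limit. Compound 3 is estimated at 45000 nM, in a range from 15000 nM to 100000 nM.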

Compound 3, half-maximal inhibitory concentration: > 50000 nM
Compound 3: a limit, no number (the forecaster's own chance of this, stated with the estimate: 55%); middle value at least 1.1-fold (0.04 log units) away from the limit.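

Compound 3, like compound 1, ends at a limit of the assay rather than a number, so no step can be read between these two compounds: the limit of > 50000 nM in this assay, at which 2 of the 3 values shown sit.

The compounds shown leave open whether replacing the 2-cyanobenzyl group on the ring nitrogen with the new group changes the result in this assay at all, and by how much.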